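Acetyl to Dimethylamino: Estimating an Untested Analogue

The compounds below may be only part of what the source reports. "The series", "measured", "known", "first", "only" and "open" are said of these compounds alone.

compound 1 `COc1cc(C)cc(-c2c(-c3ccnc(-c4ccc(C(C)=O)cc4)c3)cnn2CC#N)c1` — 10%
compound 2 `COc1cc(C)cc(-c2nn(CC#N)cc2-c2ccnc(-c3ccc(N(C)C)cc3)c2)c1` — -8%

In a functional assay on 786-0 cells (Homo sapiens) for cytotoxicity, read by sulforhodamine B assay, with a stated time of 48 h, tested at 1 uM (a higher number here means a weaker effect of the compound at the concentration tested, a lower number a stronger effect), compound 1 gives 10%, the higher of the two numbers, while compound 2 gives -8%, a gap beyond the usual scatter. Compound 3 `COc1cc(C)cc(-c2c(-c3ccnc(-c4ccc(N(C)C)cc4)c3)cnn2CC#N)c1` differs from compound 1 in one place: dimethylamino in place of acetyl on an aromatic carbon. Among the compounds with values here, no measured pair shows this exact change on its own. Compound 2 carries the same dimethylamino group and gives -8%, so a modest downward step is expected for a number 10 percentage points lower from compound 1 to compound 3 (within the scatter), probably within the scatter. Compound 3 is therefore estimated at 0%, with a range from -18% to 15%.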

Compound 3, a percentage reported as activity, at one concentration (the size of the read-out at that concentration, not a potency): 2%
Estimate against measurement, compound 3: 2 percentage points below, within the range that was stated.
By their numbers in this assay, from the lowest: compounds 2, 3 and 1 (each within the scatter of the next, the first and the last beyond it).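

In this assay the replacement of acetyl by dimethylamino on an aromatic carbon, para to a large group, now has a direct reading: it gives a number 8 percentage points lower from compound 1 to compound 3 (within the scatter). Within the data shown here, no earlier pair had isolated this change, and here 4-acetylphenyl and 4-(dimethylamino)phenyl cannot be told apart at the single concentration tested. Nothing shown offers a reason for this result. Going by these compounds, whether a carboxylic acid or a morpholine at this place would shift the number beyond the usual scatter remains open. So does whether the two groups would also match at other concentrations.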